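The source may hold more compounds than are shown below. What is called first, only, known or untested is meant among the compounds shown, and "the series" means these compounds.

Compounds measured so far:
- compound 1, `COc1cccc(/C=C/C(=O)c2c(OC)cc(OC)cc2OC)c1`: 31%
- compound 2, `COc1cc(OC)c(C(=O)/C=C/c2ccc(F)cc2)c(OC)c1`: 39%
- compound 3, `COc1cc(OC)c(C(=O)/C=C/c2ccc(Br)cc2)c(OC)c1`: 36%

These three chalcones were tested in a functional assay on Caco-2 cells (Homo sapiens), read by fluorescence and BrdU incorporation, with a stated time of 48 h, tested at 10 uM; a higher number here means a weaker effect of the compound at the concentration tested, a lower number a stronger effect. Compound 1 has the smallest number of the three, yet the steps of a number 8 percentage points higher from compound 1 to compound 2 (within the scatter) and a number 5 percentage points higher from compound 1 to compound 3 (within the scatter) both fall within the usual scatter, as does a number 3 percentage points lower from compound 2 to compound 3 (within the scatter), so the three compounds cannot be told apart on these numbers. All three measured steps change the ring at the far end of the double-bonded chain; the core of compound 1 stays the same throughout.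

Compound 4, `COc1cccc(/C=C/C(=O)c2c(O)cc(OC)cc2OC)c1`, differs from compound 1 elsewhere: hydrogen in place of methyl on an oxygen on an aromatic ring, on the core itself. Going by the values given here, none of the measured steps touches this oxygen, so no measured step bears on the change; they only show that swapping groups on the other ring left the read-out unchanged within the scatter. With nothing pointing in either direction, the expectation for compound 4 in this assay is a step of a number 1 percentage points lower from compound 1 to compound 4 (within the scatter), that is, no change beyond the scatter. Compound 4 is therefore estimated at 30%, with a range from 15% to 48%.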

Compound 4, a percentage reported as activity, at one concentration (the size of the read-out at that concentration, not a potency): 31%
The estimate for compound 4 lay 1 percentage points below the measured number, within the range that was stated.
By their numbers in this assay, from the lowest: compounds 1, 4, 3 and 2 (each within the scatter of the next).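

In this assay, going by these compounds alone, the swap of methoxy to hydroxy on this oxygen on an aromatic ring gives no change at the digits printed from compound 1 to compound 4 (within the scatter) and is the first measured change on the shared core rather than on the ring at the far end of the double-bonded chain. On these numbers compound 4 cannot be told apart from compound 1, so at this one place, hydrogen in place of methyl is tolerated as far as a single concentration in this read-out can show. No supporting data are available to explain this result.

The compounds shown leave open whether the other methoxy groups on the core would allow the same swap, and whether hydroxy here would give a similar read-out with 4-fluorophenyl or 4-bromophenyl at the far end of the chain. Going by these compounds, it also remains open how a group other than hydrogen or methyl on this oxygen, such as ethyl or a longer chain ending in an amine, would compare with compound 4.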